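A few compounds are considered here, and "the series" means these few. Any claim that something is new, unique, unknown or untested is made for them only; others in the source may bear on it.

In a functional assay for inhibition, with Rattus norvegicus as the target (a lower number here means that less compound is needed, a higher number that more compound is needed for the effect), compound 1 `CSCC[C@H](NC(=O)c1ccc(CNCCC2CCCCC2)cc1-c1ccccc1C)C(=O)O` gives 200 nM. Compound 2 `CSCC[C@H](NC(=O)c1ccc(CN[C@H](C)CC2CCCCC2)cc1-c1ccccc1C)C(=O)O` reads > 1000 nM, which is a limit of the assay and not a number. Compound 3 `CSCC[C@H](NC(=O)c1ccc(CN(CCC2CCCCC2)C(C)=O)cc1-c1ccccc1C)C(=O)O` reads > 1000 nM, which is also a limit. Going by these compounds, the data so far therefore show (the limit of > 1000 nM in this assay, at which 2 of the 3 values shown sit), and compound 3 is one of those two, so its true position is unknown.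

Compound 4 `CSCC[C@H](NC(=O)c1ccc(CN(C)CCC2CCCCC2)cc1-c1ccccc1C)C(=O)O` differs from compound 3 in one place: methyl in place of acetyl on an amine nitrogen. This puts methyl in place of acetyl on an amine nitrogen.

Within the data shown here, two measured steps bear on this change. Putting acetyl on the amine nitrogen gave an at least 5.0-fold higher number from compound 1 to compound 3 (0.69 log units; beyond the scatter), so taking the acetyl away again may recover at least part of that loss. Methyl itself is not a safe addition, however. Placed on a saturated chain carbon bound to an amine nitrogen, it gave an at least 5.0-fold higher number from compound 1 to compound 2 (0.69 log units; beyond the scatter). Among the measured compounds shown here, no measured compound carries methyl on the amine nitrogen itself, so the recovery is expected to be only partial, leaving compound 4 short of compound 1.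

A lower number in this assay is therefore expected, and the expected change is an at least 2.0-fold lower number from compound 3 to compound 4 (0.30 log units; that floor lies within the scatter). For compound 4 the estimated value is 500 nM, with an expected range from 150 nM to 1500 nM.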

Compound 4, half-maximal effective concentration: 12 nM
Beside the measured number, compound 4's estimate is 42-fold (1.62 log units) above it; measured number outside the range, below it.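

In this assay, among these compounds, the amine nitrogen proves to be a place where a small addition helps rather than harms: methyl in place of hydrogen there gives a 17-fold lower number from compound 1 to compound 4 (1.22 log units; beyond the scatter), the only step in this set that improves on compound 1. The same nitrogen and its surroundings also respond very differently to similar changes, since methyl in place of acetyl gives an at least 83-fold lower number from compound 3 to compound 4 (1.92 log units; beyond the scatter), and shifting the methyl from the saturated chain carbon onto the nitrogen itself gives an at least 83-fold lower number from compound 2 to compound 4 (1.92 log units; beyond the scatter). Those two steps start from limits of the assay and not from numbers, so their true sizes may be larger still: the limit of > 1000 nM in this assay, at which 2 of the 4 values shown sit.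

Going by these compounds, what remains open is whether the gain belongs to methyl alone or would persist with ethyl, a longer chain or a cyclopropyl group on this nitrogen. Also open, on these data alone, is whether the gain depends on the 2-cyclohexylethyl chain, or would survive if that chain were shortened or its cyclohexyl ring replaced by a phenyl ring.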